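This account rests on a few compounds, and the source may have more. Where it says the series, first, only, none or still open, it means among the compounds named here.

Working notes on the series. For the measured compounds named here, compound 2 `Nc1ncnc2c1ncn2C1O[C@H](C(=O)NC2CCCCCCC2)[C@@H](O)[C@H]1O` stands at the low end of the two numbers so far: in an assay on cell membranes for binding affinity to 2-oxoglutarate receptor 1 (Rattus norvegicus), read by radioligand binding (a higher number here means a weaker inhibitor, a lower number a stronger inhibitor), compound 2 gives 23 nM, and the nearest neighbour, compound 1 `NCCCCCCCCNC(=O)[C@H]1OC(n2cnc3c(N)ncnc32)[C@H](O)[C@@H]1O`, gives 29 nM, a gap within the scatter, so no order is read between them. Going by the values given here, the only step measured, a 1.3-fold lower number from compound 1 to compound 2 (0.10 log units; within the scatter), swaps one large group for another on the amide-type nitrogen and leaves the number unchanged. Compound 3 `Nc1ncnc2c1ncn2C1O[C@H](C(=O)NO)[C@@H](O)[C@H]1O` goes further: hydroxy in place of cyclooctyl on an amide-type nitrogen. Among the compounds with values here, no measured step covers the loss of the whole eight-membered ring, so the step from compound 2 to compound 3 rests on the structural change alone. A weaker binder is expected, with wide uncertainty; the expected step is a 17-fold higher number from compound 2 to compound 3 (1.24 log units; beyond the scatter). For compound 3 the estimate in this assay is 400 nM, with a range from 50 nM to 4000 nM.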

Compound 3, inhibition constant: 41 nM
The estimate for compound 3 lay 9.8-fold (0.99 log units) above the measured number, and the stated range ends above it.
By their numbers in this assay, from the lowest: compounds 2, 1 and 3 (each within the scatter of the next).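

At the amide-type nitrogen in this assay, hydroxy reads level with both large groups, with a 1.8-fold higher number from compound 2 to compound 3 (0.25 log units; within the scatter) and a 1.4-fold higher number from compound 1 to compound 3 (0.15 log units; within the scatter) as the two steps. For the compounds shown here, compounds 1 and 2 showed only that one large group could replace another; compound 3 adds that the cyclooctyl ring and the 8-aminooctyl chain can each give way to a single oxygen with no step beyond the scatter, so across these three compounds the size of this group does not separate the numbers. No supporting evidence bears on why these numbers stay level.

Only three groups at this nitrogen are shown, all within the scatter of one another. As far as these compounds go, whether a methoxy, an ethyl or a phenyl group there would keep the number in the same range remains open.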